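From Compound 3 to Compound 4: Benzoyl in Place of Phenyl

The source may report more compounds than this note shows. Statements on the series, on what has been measured and on what is new or still open speak of the compounds shown alone.

Compound 1 `Cc1nnc(SCC(=O)c2ccccc2)n1N1C(=O)c2ccccc2C1=O` gives > 200000 nM in a functional assay on PC-3M cells (Homo sapiens) for cytotoxicity, read by MTT assay, with a stated time of 48 h (a lower number here means a stronger inhibitor, a higher number a weaker inhibitor), a limit of the assay.
Compound 2 `C#CCSc1nnc(CC)n1N1C(=O)c2ccccc2C1=O` gives > 200000 nM in this assay, again a limit.
Compound 3 `CCc1nnc(SCc2ccccc2)n1N1C(=O)c2ccccc2C1=O` gives > 200000 nM in this assay, also a limit.

Compound 3 therefore stands at a limit, and the two other values shown are limits as well, so no order among these three compounds can be read. For the measured compounds named here, the one step between two measured neighbours, a step that the two limits leave unreadable from compound 2 to compound 3, is unreadable for the same reason. Compound 4 `CCc1nnc(SCC(=O)c2ccccc2)n1N1C(=O)c2ccccc2C1=O` is the compound still to be measured; it differs from compound 3 by benzoyl in place of phenyl on a saturated chain carbon bound to a sulfur. The same benzoylmethyl group on sulfur is already present in compound 1, which sits at the limit, and the limit of > 200000 nM in this assay, at which 3 of the 3 values shown sit, describes where all measured values sit. No readable step bears on the change, so a step of no particular size or direction is expected: a step that the limit leaves unreadable from compound 3 to compound 4. Compound 4 is estimated at 300000 nM, within 100000 nM to 1000000 nM.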

Compound 4, half-maximal inhibitory concentration: > 200000 nM
Compound 4 gave a limit, no number; the forecaster's own chance of this, stated with the estimate: 85%; the middle value is on the limit's open side.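

For the compounds shown here, compound 4 also stands at a limit, so no step linking it to compound 1, compound 2 or compound 3 can be read: the limit of > 200000 nM in this assay, at which 4 of the 4 values shown sit. The compounds shown leave open whether any group on the sulfur changes the result in this assay at all.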